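Substituent change at the shared core: compound 3 to compound 4

A few compounds are considered here, and "the series" means these few. Any claim that something is new, unique, unknown or untested is made for them only; others in the source may bear on it.

In a functional assay on SKW3 cells (Homo sapiens) for antiproliferative activity, read by WST assay, with a stated time of 3 days (on this read-out lower numbers stand for stronger inhibition and higher numbers for weaker inhibition), compound 3 `COC(=O)c1cc(=O)[nH]c(=O)n1[C@@H]1O[C@H](CO)[C@@H](O)[C@H]1O` gives only a limit, > 50000 nM. Compound 1 `N#Cc1cc(=O)[nH]c(=O)n1[C@@H]1O[C@H](CO)[C@@H](O)[C@H]1O` likewise gives a limit, > 50000 nM. Compound 2 `Nc1cc(=O)[nH]c(=O)n1[C@@H]1O[C@H](CO)[C@@H](O)[C@H]1O` also gives a limit, > 50000 nM. For the measured compounds named here, all three values sit at the same limit (the limit of > 50000 nM in this assay, at which 3 of the 3 values shown sit), so the steps a step that the two limits leave unreadable from compound 1 to compound 2, a step that the two limits leave unreadable from compound 1 to compound 3 and a step that the two limits leave unreadable from compound 2 to compound 3 cannot be sized, and the series so far holds no compound with a measured number. Compound 4 `CN(C)c1cc(=O)[nH]c(=O)n1[C@@H]1O[C@H](CO)[C@@H](O)[C@H]1O` differs from compound 3 by dimethylamino in place of methoxycarbonyl on an aromatic carbon. Going by the values given here, no measured step bears readably on this change. The step is expected to be a number no higher from compound 3 to compound 4 (the limit leaves the size open), nominal only, with the assay most likely reporting a limit once more. Compound 4 is estimated at 50000 nM, in the range 15000 nM to 200000 nM.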

Compound 4, half-maximal inhibitory concentration: > 50000 nM
Compound 4 was reported as a limit; the forecaster's own chance of this, stated with the estimate: 85%; the middle value sits exactly at the limit.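

For the compounds shown here, compound 4 gives only a limit, > 50000 nM, so no step linking it to compound 1, compound 2 or compound 3 can be read. Whether any substituent at this place on the shared core gives a measurable number stays open: the limit of > 50000 nM in this assay, at which 4 of the 4 values shown sit.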